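The compounds below may be only part of what the source reports. "The series", "measured", "known", "first", "only" and "open" are said of these compounds alone.

Compound 1 (`O=C1NC(O)(CCn2cnc3cc[nH]c3c2=O)C(OCc2ccccc2)=C1OCc1ccccc1`) is the starting point. Going by the values given here, in a functional assay on L1210/0 cells (Mus musculus) for antiproliferative activity, read by MTT assay, with a stated time of 72 h (on this read-out lower numbers stand for stronger inhibition and higher numbers for weaker inhibition), compound 1 gives 107000 nM, the highest single number so far. That lies well beyond the scatter from compound 2 (`O=C1O/C(=C\Cn2cnc3cncc(Br)c32)C(OCc2ccccc2)=C1OCc1ccccc1`), where compound 2 gives 6800 nM. Compound 3 (`O=C1NC(O)(CCn2cnc3ccn(CCC4(O)NC(=O)C(OCc5ccccc5)=C4OCc4ccccc4)c3c2=O)C(OCc2ccccc2)=C1OCc1ccccc1`) has two entries, and compound 3 reads 4400 nM; 7600 nM (2 entries).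

Compound 4 (`O=C1NC(O)(CCn2cnc3cncc(Br)c32)C(OCc2ccccc2)=C1OCc1ccccc1`) is still unmeasured. It keeps the rest of compound 1 and exchanges one group, on a saturated chain carbon, two bonds along the chain from a saturated ring carbon: a group of 10 heavy atoms (6 carbon, 3 nitrogen, 1 bromine; one five-membered aromatic ring with 2 hetero atoms, one six-membered aromatic ring with 1 hetero atom) in place of a group of 10 heavy atoms (6 carbon, 3 nitrogen, 1 oxygen; one five-membered aromatic ring with 1 hetero atom, one six-membered aromatic ring with 2 hetero atoms), on a saturated chain carbon, two bonds along the chain from a saturated ring carbon. Among the compounds with values here, no measured pair isolates this exchange, so any forecast is uncertain. Compound 2, at 6800 nM, carries the same bromine-bearing group on a different framework, so a moderate fall in the number in this assay, beyond the scatter, is expected, though probably not to that level. The expected change is a 3.6-fold lower number from compound 1 to compound 4 (0.55 log units; beyond the scatter). For compound 4, the estimated value is 30000 nM, with an expected range of 8000 nM to 110000 nM.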

Compound 4, half-maximal inhibitory concentration: 50000 nM
Compound 4: middle estimate off by 1.7-fold (0.22 log units), on the low side; low and high end bracket the measured number.
By their numbers in this assay, from the lowest: compound 2; then compound 4; then compound 1.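

In this assay, going by these compounds alone, the exchange at this place, on a saturated chain carbon, gives a 2.1-fold lower number from compound 1 to compound 4 (0.33 log units; beyond the scatter), so this is the first measured sign that the group there affects the number. The step is modest, though it lies beyond the scatter, and repeat readings of a single compound can themselves differ visibly: the several entries of compound 3 in this assay, 4400 nM; 7600 nM (2 entries). The exchange also changes several things at once, as the entering group brings in a bromine and has no hydrogen-bond donor, so this single step cannot separate their contributions.

The compounds shown leave open whether the bromine itself matters, which a matching group carrying chlorine or plain hydrogen in its place could test. They also leave open how a longer chain, or an amine on the same group, would change the number.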